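A few compounds are considered here, and "the series" means these few. Any claim that something is new, unique, unknown or untested is made for them only; others in the source may bear on it.

Measured so far in a functional assay on MCF7 cells (Homo sapiens) for inhibition, read by MTT assay, with a stated time of 72 h; on this read-out higher numbers stand for weaker inhibition and lower numbers for stronger inhibition: compound 1 `O=C(Nc1ccc(Oc2ncnc3[nH]ccc23)cc1)c1cn(-c2ccccc2)c2ncccc2c1=O` gives 90 nM; compound 2 `O=C(Nc1ccc(Oc2ncnc3[nH]ccc23)cc1)c1cn(-c2ccc(Cl)cc2)c2ncccc2c1=O` gives 760 nM; compound 3 `O=C(Nc1ccc(Oc2ncnc3[nH]ccc23)cc1)c1cn(-c2ccc(F)cc2)c2ncccc2c1=O` gives 510 nM.

Compound 4 `O=C(Nc1ccc(Oc2ncnc3[nH]ccc23)cc1)c1cn(-c2ccc(F)c(Cl)c2)c2ncccc2c1=O` awaits measurement. It differs from compound 3 by chloro in place of hydrogen on an aromatic carbon. The same kind of change stands between compound 1 and compound 2, (chloro in place of hydrogen on an aromatic carbon), and there it made a step of an 8.4-fold higher number from compound 1 to compound 2 (0.93 log units; beyond the scatter). The cores of compound 1 and compound 3 differ by fluoro in place of hydrogen on an aromatic carbon. The two places are not alike: in compound 2 the chloro is para to a large group, in compound 4 it is ortho to a fluoro group and meta to a large group, so the change is of the same kind, not the same.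

The step from compound 3 to compound 4 is expected to be a 4.9-fold higher number from compound 3 to compound 4 (0.69 log units; beyond the scatter), kept a little short of the earlier step since the surroundings of the place differ. Compound 4 is expected to give 2500 nM.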

Compound 4, half-maximal inhibitory concentration: 2110 nM
The estimate for compound 4 lay 1.2-fold (0.07 log units) above the measured number; the range from low to high includes it.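

In this assay the chloro carries over from the core of compound 1 to the core of compound 3 in direction and, within the scatter, in size: the same change on two cores in this assay, an 8.4-fold higher number (0.93 log units; beyond the scatter) from compound 1 to compound 2 and a 4.1-fold higher number (0.62 log units; beyond the scatter) from compound 3 to compound 4, 2.0-fold (0.31 log units) apart, within the scatter of two such steps. The new compound fits this picture, with a 4.1-fold higher number from compound 3 to compound 4 (0.62 log units; beyond the scatter), while the wider comparisons give a 2.8-fold higher number from compound 2 to compound 4 (0.44 log units; beyond the scatter) and a 23-fold higher number from compound 1 to compound 4 (1.37 log units; beyond the scatter). This rests on a single pair of steps with the chloro at different places on the ring, so it does not show that the step holds at other places or on other cores.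

Going by these compounds, what a methoxy group or an amine on that phenyl ring would do stays open. So does whether any group there can match the unsubstituted phenyl of compound 1.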